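The compounds below may be only part of what the source reports. "The series", "measured", "known", "first", "only" and "open" are said of these compounds alone.

The three measured compounds are compound 1 `O=c1n(CCCCCCN2CCN(c3cccc4ccccc34)CC2)nc2ccccn12`, compound 2 `NC(=O)N1CCN(c2cccc(Cl)c2)CC1` and compound 3 `NS(=O)(=O)NCCCCCCN1CCN(c2cccc(Cl)c2)CC1`. In an assay on HEK293 cells for displacement of a labelled ligand from 5-hydroxytryptamine receptor 6 (Homo sapiens), read by radioligand binding (a lower number here means a stronger inhibitor, a higher number a weaker inhibitor), compound 1 gives 285 nM, compound 2 gives 7490 nM and compound 3 gives 1530 nM. Compound 1 shows the lowest number of the three, and its gaps to compound 3 and to compound 2 both lie beyond the scatter, so it is the strongest inhibitor of this set. Compound 4 `O=c1n(CCCCCCN2CCN(c3cccc4cccnc34)CC2)nc2ccccn12` has not yet been measured in this assay. It differs from compound 1 in one place: quinolin-8-yl in place of naphthalen-1-yl on an amine nitrogen in a ring. Among the compounds with values here, no measured pair shows a change of this kind, so nothing here tells its size directly. A small step toward a somewhat higher number is expected, namely a 1.5-fold higher number from compound 1 to compound 4 (0.17 log units; within the scatter). Compound 4 is therefore estimated to give 420 nM in this assay, with a range from 150 nM to 1200 nM.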

Compound 4, inhibition constant: 4140 nM
Compound 4: the middle estimate sits 9.9-fold (0.99 log units) below what was measured; measured number above the stated range.
By their numbers in this assay, from the lowest: compound 1; then compound 3; then compounds 4 and 2 (each within the scatter of the next).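

At this place on the ring amine nitrogen, quinolin-8-yl in place of naphthalen-1-yl gives a 15-fold higher number from compound 1 to compound 4 (1.16 log units; beyond the scatter) in this assay. The group that enters has the same heavy-atom count as the one that leaves, differing by one ring nitrogen and one hydrogen-bond acceptor, so even this small exchange is not neutral in this series. Nothing shown gives a reason for the step.

The compounds shown leave open whether isoquinolin-5-yl or plain phenyl at this place would behave like quinolin-8-yl or like naphthalen-1-yl. They also leave open whether a shorter chain would change the size of this step.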